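The source may report more compounds than this note shows. Statements on the series, on what has been measured and on what is new or still open speak of the compounds shown alone.

Working notes on the series: in a physicochemical assay for lipophilicity, measured as octanol-water partition (on this read-out higher numbers stand for higher lipophilicity and lower numbers for lower lipophilicity), compound 2 `O=C(NNc1ccnc2cc(Cl)ccc12)c1ccccc1/N=C/c1ccc(O)cc1` gives 4.65, the lower of the two numbers so far, and compound 1 `O=C(NNc1ccnc2cc(Cl)ccc12)c1ccccc1/N=C/c1cccc(Cl)c1Cl` gives 6.1. Compound 3 `O=C(NNc1ccnc2cc(Cl)ccc12)c1ccccc1/N=C/c1cccs1` has thiophen-2-yl in place of 4-hydroxyphenyl on a carbon with a double bond to nitrogen. Going by the values given here, the only measured step at this place is a number 1.45 log units lower from compound 1 to compound 2 (beyond the scatter), which is large and beyond the scatter. Only part of that size is expected to be regained, as a moderate rise in this assay, since thiophen-2-yl matches neither group measured here. The expected step is a number 0.50 log units higher from compound 2 to compound 3 (beyond the scatter). Compound 3 is estimated at 5.15, with an expected range of 4.7 to 5.6.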

Compound 3, partition coefficient: 4.78
Compound 3: middle estimate off by 0.37 log units, on the high side, and the stated range covers the measured number.
By their numbers in this assay, from the lowest: compounds 2 and 3 (each within the scatter of the next); then compound 1.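

In this assay, replacing 4-hydroxyphenyl with thiophen-2-yl gives a number 0.13 log units higher from compound 2 to compound 3 (within the scatter), so these two groups are not separated at this place on the carbon with a double bond to nitrogen. Replacing 2,3-dichlorophenyl with thiophen-2-yl gives a number 1.32 log units lower from compound 1 to compound 3 (beyond the scatter), so 2,3-dichlorophenyl now stands apart from two different groups, not just one. No supporting data bear on the reason for this.

From the compounds shown here alone, whether unsubstituted phenyl or a phenyl carrying a single chlorine would stay with compound 2 and compound 3 or move towards compound 1 remains open. So does the reading for a carboxylic acid or an amine at this place.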